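Shortening the amine tail: from compound 1 to compound 4

The source may report more compounds than this note shows. Statements on the series, on what has been measured and on what is new or still open speak of the compounds shown alone.

Compound 1 `CN1CCN(CCCCn2c3c(c4ccccc42)C(=O)c2c[n+]([O-])c4ccccc4c2C3=O)CC1` is the reference point of this small set. In a functional assay on A-375 cells (Homo sapiens) for cytotoxicity, read by MTT assay, with a stated time of 72 h (on this read-out lower numbers stand for stronger inhibition and higher numbers for weaker inhibition), compound 1 gives 30 nM, the lowest number of the three measured compounds. For the measured compounds named here, compound 2 `CC1(C)OC[C@@H](Cn2cc(Cn3c4c(c5ccccc53)C(=O)c3c[n+]([O-])c5ccccc5c3C4=O)nn2)O1` gives 450 nM in this assay, and compound 3 `O=C1c2c[n+]([O-])c3ccccc3c2C(=O)c2c1c1ccccc1n2Cc1cn([C@H]2C[C@H](O)[C@@H](CO)O2)nn1` gives 390 nM; the only measured single-point step, a 1.2-fold lower number from compound 2 to compound 3 (0.06 log units; within the scatter), lies within the scatter. Both of these stand well above compound 1, and both carry a triazole-linked substituent on the aromatic nitrogen rather than a chain ending in an amine.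

Compound 4 `CN(C)CCCCn1c2c(c3ccccc31)C(=O)c1c[n+]([O-])c3ccccc3c1C2=O` differs from compound 1 in one place: dimethylamino in place of 4-methylpiperazin-1-yl on a saturated chain carbon, four bonds along the chain from an aromatic nitrogen. Going by the values given here, no measured step bears directly on this exchange. The step from compound 2 to compound 3 concerns a different substituent on the aromatic nitrogen and was flat, so it neither supports nor contradicts a shift here. Compound 4 keeps a tertiary amine at the same point of the chain as compound 1, and the exchange removes only the ring around that nitrogen. On that basis the step of a 1.5-fold higher number from compound 1 to compound 4 (0.18 log units; within the scatter) is expected to be small, at most a modest weakening, and not clearly beyond the scatter. Compound 4 is therefore estimated at 45 nM in this assay, within a range of 15 nM to 130 nM.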

Compound 4, half-maximal inhibitory concentration: 470 nM
Beside the measured number, compound 4's estimate is 10-fold (1.02 log units) below it; the measured number lies above the stated range.
By their numbers in this assay, from the lowest: compound 1; then compounds 3, 2 and 4 (each within the scatter of the next).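

In this assay the exchange of 4-methylpiperazin-1-yl for dimethylamino on a saturated chain carbon, four bonds along the chain from an aromatic nitrogen, gives a 16-fold higher number from compound 1 to compound 4 (1.19 log units; beyond the scatter) and so marks this position as sensitive to the group at the end of the chain. The earlier step of a 1.2-fold lower number from compound 2 to compound 3 (0.06 log units; within the scatter) was flat, but it concerned a different substituent on the aromatic nitrogen and gave no sign of this sensitivity. An amine at this point of the chain is thus not enough on its own to keep the low number of compound 1, and the result depends on what 4-methylpiperazin-1-yl carries beyond that nitrogen, though nothing available explains the size of the step.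

The compounds shown do not separate the ring from the second ring nitrogen, a question that piperidin-1-yl or morpholin-4-yl on the same chain would address. Also open, going by these compounds, is whether 4-methylpiperazin-1-yl keeps its advantage over dimethylamino on a shorter or longer chain, or whether the same exchange gives a step of similar size there.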